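Thiazole in place of phenyl on the sulfonyl group

The source may hold more compounds than are shown below. What is called first, only, known or untested is meant among the compounds shown, and "the series" means these compounds.

Compound 1, `CCCCc1ccc(CN(c2ccccc2CCCC(=O)O)S(C)(=O)=O)cc1`, gives 494 nM in an assay on HEK293 cells for inhibition of prostaglandin E2 receptor EP2 subtype (Rattus norvegicus); on this read-out lower numbers stand for stronger inhibition and higher numbers for weaker inhibition.
Compound 2, `CC(C)(C)c1ccc(CN(Cc2cccc(CCC(=O)O)c2)S(=O)(=O)c2ccccc2)cc1`, gives 278 nM in this assay.

In this assay compound 2 gives 278 nM, the smaller of the two numbers, yet compound 1 with 494 nM sits within the usual scatter of it, so the two are not told apart. Compound 3, `CC(C)(C)c1ccc(CN(Cc2cccc(CCC(=O)O)c2)S(=O)(=O)c2nccs2)cc1`, differs from compound 2 by 1,3-thiazol-2-yl in place of phenyl on a sulfonyl sulfur. Among the compounds with values here, no pair of measured compounds shows this change, so nothing is known of its size; the expectation is a step of a 1.1-fold higher number from compound 2 to compound 3 (0.03 log units; within the scatter) that stays within the scatter of this assay. Compound 3 is therefore estimated at 300 nM, in the range 100 nM to 900 nM.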

Compound 3, half-maximal inhibitory concentration: 63 nM
Estimate against measurement, compound 3: 4.8-fold (0.68 log units) above; the whole stated range lies above it.
By their numbers in this assay, from the lowest: compound 3; then compounds 2 and 1 (each within the scatter of the next).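

The ring on the sulfonyl sulfur matters in this assay: 1,3-thiazol-2-yl in place of phenyl gives a 4.4-fold lower number from compound 2 to compound 3 (0.64 log units; beyond the scatter) and so moves the number beyond the scatter, which the comparison of compound 1 with compound 2 could not show. The new ring is a five-membered aromatic ring with 2 hetero atoms, and nothing measured here gives a reason for the step. Whether the ring nitrogen or the ring sulfur accounts for it stays open; a thiophen-2-yl or pyridin-2-yl group on the sulfonyl sulfur would bear on that.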